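The source may hold more compounds than are shown below. What is called first, only, known or untested is meant among the compounds shown, and "the series" means these compounds.

Measured so far in a physicochemical assay for lipophilicity, measured as octanol-water partition, at pH 7.4; on this read-out higher numbers stand for higher lipophilicity and lower numbers for lower lipophilicity
- compound 1 `Cc1nc(N)c2c(n1)N(Cc1ccccc1)C(=O)C2` gives 2
- compound 2 `COCCCc1cc2c([nH]c(=O)n2Cc2ccccc2)c(N)n1` gives "not determined" (no result reported)

Compound 2 therefore has no number in this series and offers no starting point of its own. Compound 3 `Nc1nccc2c1[nH]c(=O)n2Cc1ccccc1` remains unmeasured. The step to follow is hydrogen in place of 3-methoxypropyl on an aromatic carbon and sets hydrogen in place of 3-methoxypropyl on an aromatic carbon. A moderate downward step in this assay is expected, somewhat beyond the scatter, though it cannot be sized from compound 2. Going by the values given here, the only numerical anchor is compound 1 at 2 and the estimate leans on it. For compound 3 the expected value is 1.7 (estimated range 1.1 to 2.3).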

Compound 3, distribution coefficient: 1.9
The estimate for compound 3 lay 0.20 log units below the measured number; the range from low to high includes it.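

Going by these compounds alone, compound 2 has no number in this assay, so no step from it to compound 3 can be read. The compounds shown leave open how 3-methoxypropyl compares with hydrogen on this read-out. No evidence bears on the result.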